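The source may hold more compounds than are shown below. What is called first, only, known or untested is meant among the compounds shown, and "the series" means these compounds.

Compound 3 `c1cncc(-n2cc(CSc3nc4ccccc4s3)nn2)c1` is one of three compounds sharing a core in which a triazole carries a different group on its aromatic nitrogen. In a functional assay on the whole organism (strain Albino Wistar) for inhibition, with Rattus norvegicus as the target, read by paw edema, with stated times of 1 h and 5 h, at a dose of 10 mg/kg by the oral route (a higher number here means more inhibition at the dose given (going by the name of the read-out), a lower number less inhibition), compound 3 gives 56%, the second highest of the three numbers. Compound 1 `Fc1ccc(-n2cc(CSc3nc4ccccc4s3)nn2)cc1` gives 81.1%, and compound 2 `Cc1ccccc1-n1cc(CSc2nc3ccccc3s2)nn1` gives 43.4%. The steps between these three all swap one aryl group for another on the aromatic nitrogen: a number 37.7 percentage points lower from compound 1 to compound 2 (beyond the scatter), a number 25.1 percentage points lower from compound 1 to compound 3 (beyond the scatter) and a number 12.6 percentage points higher from compound 2 to compound 3 (beyond the scatter). Together they show that this position can move the read-out well beyond the scatter in either direction.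

Compound 4 `CC1(C)OCC(Cn2cc(CSc3nc4ccccc4s3)nn2)O1` differs from compound 3 as follows: (2,2-dimethyl-1,3-dioxolan-4-yl)methyl in place of pyridin-3-yl on an aromatic nitrogen. Within the data shown here, no measured step replaces an aryl group with a non-aromatic group, so none bears directly on this change; the three aryl swaps only indicate that the substituent on the aromatic nitrogen matters. Given the size of the measured steps, a modest downward step is expected, a number 11 percentage points lower from compound 3 to compound 4 (beyond the scatter), with wide uncertainty. Compound 4 is therefore estimated at 45%, in the range 20% to 70%.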

Compound 4, a percentage reported as inhibition, in the whole organism at one dose (the size of the read-out at that dose, not a potency): 49.1%
The estimate for compound 4 lay 4.1 percentage points below the measured number; low and high end bracket the measured number.
By their numbers in this assay, from the lowest: compounds 2, 4 and 3 (each within the scatter of the next, the first and the last beyond it); then compound 1.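

Compound 4 shows that an aromatic ring on the aromatic nitrogen is not needed to reach this level in this assay: the (2,2-dimethyl-1,3-dioxolan-4-yl)methyl group gives a number 6.9 percentage points lower from compound 3 to compound 4 (within the scatter) and a number 5.7 percentage points higher from compound 2 to compound 4 (within the scatter), so it cannot be told apart from pyridin-3-yl or 2-methylphenyl. The 4-fluorophenyl group alone stands apart from it, with a number 32 percentage points lower from compound 1 to compound 4 (beyond the scatter), so among these four compounds the large change at this position follows that one group and not the split between aromatic and non-aromatic rings. Nothing available explains these steps.

The compounds shown leave open whether plain phenyl, without the fluorine, would keep the number of compound 1. They also leave open how a longer alkyl chain, an amine or a carboxylic acid on this nitrogen would read out.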